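Bcl-2 acylsulfonamide series: ether-for-amine swap at the nitroaryl

The source may hold more compounds than are shown below. What is called first, only, known or untested is meant among the compounds shown, and "the series" means these compounds.

Measured so far:
compound 1 `CC1(C)CCC(CN2CCN(c3ccc(C(=O)NS(=O)(=O)c4ccc(NCC5CCOCC5)c([N+](=O)[O-])c4)c(Oc4cnc5[nH]ccc5c4)c3)CC2)=C(c2ccc(Cl)cc2C(F)(F)F)C1` — 0.86 nM
compound 2 `CC1(C)CCC(CN2CCN(c3ccc(C(=O)NS(=O)(=O)c4ccc(NCC5CCOC5)c([N+](=O)[O-])c4)c(Oc4cnc5[nH]ccc5c4)c3)CC2)=C(c2ccc(C(F)(F)F)cc2)C1` — 4.7 nM

Two compounds have numbers in an assay on isolated protein for displacement of a labelled ligand from Apoptosis regulator Bcl-2 (Homo sapiens), with a stated time of 15 min; a higher number here means a weaker inhibitor, a lower number a stronger inhibitor. Compound 1 gives 0.86 nM. Compound 2 gives 4.7 nM, the higher of the two, and the gap to compound 1 lies beyond the scatter; the two differ in more than one place, so no single change can be credited.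

Compound 3 `CC1(C)CCC(CN2CCN(c3ccc(C(=O)NS(=O)(=O)c4ccc(OCC5CCSCC5)c([N+](=O)[O-])c4)c(Oc4cnc5[nH]ccc5c4)c3)CC2)=C(c2ccc(C(F)(F)F)cc2)C1` follows from compound 2 by one change: a group of 8 heavy atoms (6 carbon, 1 oxygen, 1 sulfur; one six-membered non-aromatic ring with 1 hetero atom) in place of a group of 7 heavy atoms (5 carbon, 1 nitrogen, 1 oxygen; one five-membered non-aromatic ring with 1 hetero atom), on an aromatic carbon. The hydrogen-bond donor of the leaving group is gone and the ring grows by one member, with the ether oxygen now the link to the aromatic carbon ortho to the nitro group. No step of this kind is shown among the measured pairs, so the direction rests on the structural change alone. A modest loss is expected rather than a gain, with a 2.3-fold higher number from compound 2 to compound 3 (0.37 log units; beyond the scatter) as the expected step. For compound 3 the estimate in this assay is 11 nM, within 3.5 nM to 35 nM.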

Compound 3, half-maximal inhibitory concentration: 1.65 nM
Estimate against measurement, compound 3: 6.7-fold (0.82 log units) above, outside the stated range (below it).
By their numbers in this assay, from the lowest: compounds 1 and 3 (each within the scatter of the next); then compound 2.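

In this assay the place ortho to a nitro group accepts a larger group without loss, with a 2.8-fold lower number from compound 2 to compound 3 (0.45 log units; beyond the scatter) on replacing ((oxolan-3-yl)methyl)amino by a group with a six-membered non-aromatic ring holding sulfur. The entering group carries no hydrogen-bond donor, and compound 3 still gives 1.65 nM, so a donor at this place is not required for a number in this range. No measurement on hand bears on why the number moves in this direction.

The step changes the link to the aromatic carbon, the ring size and the ring hetero atom together, and the share of each remains unresolved. A (thian-4-yl)methylamino group or an (oxolan-3-yl)methoxy group on the core of compound 2 would separate the link from the ring.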